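The source may report more compounds than this note shows. Statements on the series, on what has been measured and on what is new or still open speak of the compounds shown alone.

Working notes on the series.

Compound 1 `COc1cc(-c2nnc3n2NC(c2ccco2)C(C(=O)c2ccccc2F)S3)cc(OC)c1OC` gives 78700 nM in a functional assay on A549 cells (Homo sapiens) for cytotoxicity, read by MTT assay, with a stated time of 48 h; a higher number here means a weaker inhibitor, a lower number a stronger inhibitor. Compound 2 `COc1cc(-c2nnc3n2NC(c2ccco2)C(C(=O)C2CC2)S3)cc(OC)c1OC` reaches only the limit of the assay, > 100000 nM, so for compound 2 there is no number, only a limit. The step of an at least 1.2-fold higher number from compound 1 to compound 2 (0.10 log units; that floor lies within the scatter) is therefore bounded by the limit of > 100000 nM in this assay, at which 1 of the 2 values shown sits, and its floor lies within the scatter.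

Compound 3 `COc1ccc(C(=O)C2Sc3nnc(-c4cc(OC)c(OC)c(OC)c4)n3NC2c2ccco2)cc1` differs from compound 2 by 4-methoxyphenyl in place of cyclopropyl on a carbonyl carbon. Within the data shown here, the only measured step in this assay is the one from compound 1 to compound 2, an exchange of an aryl ketone for a cyclopropyl ketone, which moved the number upward only to the limit; the reverse direction, aryl in place of cyclopropyl, is the change now in hand. Because an at least 1.2-fold higher number from compound 1 to compound 2 (0.10 log units; that floor lies within the scatter) shows no shift beyond the scatter, the step of an at least 1.2-fold lower number from compound 2 to compound 3 (0.09 log units; that floor lies within the scatter) is expected to be small, if anything back toward the number of compound 1. Compound 3 is estimated at 80000 nM, within 40000 nM to 160000 nM, with a fair chance that this assay again reports only a limit.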

Compound 3, half-maximal inhibitory concentration: > 100000 nM
Compound 3 was reported as a limit (the forecaster's own chance of this, stated with the estimate: 40%); middle value at least 1.2-fold (0.09 log units) from the limit.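

In this assay the result for compound 3 is a limit and not a number, so an aryl ketone, 4-methoxyphenyl, now stands at the same limit as the cyclopropyl ketone, and the step between those two compounds cannot be read. The exchange of 2-fluorophenyl for 4-methoxyphenyl on a carbonyl carbon gives an at least 1.2-fold higher number from compound 1 to compound 3 (0.10 log units; that floor lies within the scatter), so an aryl group at this position does not by itself bring a measured number. What this position can show is now bounded by the assay limit: the limit of > 100000 nM in this assay, at which 2 of the 3 values shown sit.

As far as these compounds go, whether any group here gives a number clearly beyond the scatter from that of compound 1 stays open. A ketone carrying an amine, a carboxylic acid or a longer alkyl chain is not among the compounds shown, and neither is a 4-fluorophenyl ketone.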